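This account rests on a few compounds, and the source may have more. Where it says the series, first, only, none or still open, it means among the compounds named here.

Measured so far:
Compound 1 `CCOC(=O)c1cnc(-c2cccs2)nc1NN1C(=O)C=C(C)C1=O`: in a functional assay on Jurkat cells for inhibition of nuclear factor NF-kappa-B complex (Homo sapiens) (a higher number here means a weaker inhibitor, a lower number a stronger inhibitor), compound 1 gives 20 nM.
Compound 2 `CCOC(=O)c1cnc(-n2nc(C)cc2C)nc1NN1C(=O)C=C(C)C1=O`: in this assay compound 2 gives 10000 nM.
Compound 3 `CCOC(=O)c1cnc(-c2ccc(Cl)cc2)nc1NN1C(=O)C=C(C)C1=O`: in this assay compound 3 gives 300 nM.

Compound 2 has the highest number of the three, so it is the weakest inhibitor here, and both steps away from it are beyond the scatter: a 33-fold lower number from compound 2 to compound 3 (1.52 log units; beyond the scatter), while in the other direction a 500-fold higher number from compound 1 to compound 2 (2.70 log units; beyond the scatter).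

Compound 4 `CCOC(=O)c1cnc(-c2ccc(Cl)s2)nc1NN1C(=O)C=C(C)C1=O` is not yet measured. It differs from compound 2 in one place: 5-chlorothiophen-2-yl in place of 3,5-dimethyl-1H-pyrazol-1-yl on an aromatic carbon. The entering group is the thiophen-2-yl of compound 1 carrying an extra chlorine. Going by the values given here, two measured steps bear on this change. a 500-fold higher number from compound 1 to compound 2 (2.70 log units; beyond the scatter) shows that the dimethylpyrazolyl group cost a very large amount relative to the plain thiophene, and a 33-fold lower number from compound 2 to compound 3 (1.52 log units; beyond the scatter) shows that replacing it with a carbon aromatic ring recovers much of that. Among the compounds with values here, no measured pair separates a chlorinated thiophene from a plain one, so that part is open. A large drop in the number is therefore expected, a 200-fold lower number from compound 2 to compound 4 (2.30 log units; beyond the scatter). Compound 4 is estimated at 50 nM, with a range from 10 nM to 400 nM.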

Compound 4, half-maximal inhibitory concentration: 300 nM
Compound 4: middle estimate off by 6.0-fold (0.78 log units), on the low side, within the range that was stated.
By their numbers in this assay, from the lowest: compound 1; then compounds 3 and 4 (each within the scatter of the next); then compound 2.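

Putting 5-chlorothiophen-2-yl in place of 3,5-dimethyl-1H-pyrazol-1-yl gives a 33-fold lower number from compound 2 to compound 4 (1.52 log units; beyond the scatter) in this assay and so recovers only part of what the pyrazole lost, since the single added chlorine on the thiophene of compound 1 gives a 15-fold higher number from compound 1 to compound 4 (1.18 log units; beyond the scatter) on its own. Swapping the chlorinated thiophene against the chlorinated benzene ring gives no change at the digits printed from compound 3 to compound 4 (within the scatter) and so separates these two groups at this position no further, which means the advantage of compound 1 does not survive in its chlorinated form. No measurement here explains the cost of the chlorine.

On these data alone, whether that cost belongs to chlorine itself or to any group at that place on the thiophene stays open; a methyl or a methoxy group there would help to tell. A plain phenyl ring would show whether the chlorine of compound 3 carries a similar cost.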